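Compound 3 to compound 4: a ring swap near the limit

A few compounds are considered here, and "the series" means these few. Any claim that something is new, unique, unknown or untested is made for them only; others in the source may bear on it.

In a functional assay on HepG2 cells (Homo sapiens) for antiproliferative activity, read by MTT assay, with a stated time of 48 h (a higher number here means a weaker inhibitor, a lower number a stronger inhibitor), compound 3 (`O=C(CN1CCCC1)Nc1ccc2ncnc(Nc3ccc(Br)cc3)c2c1`) gives > 100000 nM, a limit and not a number. Compound 1 (`O=C(CN1CCCCC1)Nc1ccc2ncnc(Nc3cccc(C(F)(F)F)c3)c2c1`) gives > 100000 nM, also a limit. Compound 2 (`O=C(CN1CCCCC1)Nc1ccc2ncnc(Nc3cccc(Cl)c3)c2c1`) gives 12000 nM.

Compound 4 (`O=C(CN1CCCCC1)Nc1ccc2ncnc(Nc3ccc(Br)cc3)c2c1`) carries piperidin-1-yl in place of pyrrolidin-1-yl on a saturated chain carbon bound to a carbonyl carbon. For the measured compounds named here, the only measured step, an at least 8.3-fold lower number from compound 1 to compound 2 (0.92 log units; beyond the scatter), is chloro in place of trifluoromethyl on an aromatic carbon, so it does not size this ring change. Going by the values given here, no measured step covers the ring change itself, and no shift beyond the scatter is expected. The series still leans on (the limit of > 100000 nM in this assay, at which 2 of the 3 values shown sit). The expected step is a number no higher from compound 3 to compound 4 (the limit leaves the size open). For compound 4 the estimate is 100000 nM, with an expected range of 20000 nM to 200000 nM.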

Compound 4, half-maximal inhibitory concentration: > 100000 nM
Compound 4: a limit, no number (the forecaster's own chance of this, stated with the estimate: 60%); the middle value lies on the limit itself.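

The ring change from pyrrolidin-1-yl to piperidin-1-yl on a saturated chain carbon bound to a carbonyl carbon gains no size in this assay, and the steps from compound 3 and from compound 1 to compound 4 cannot be read. With piperidin-1-yl held constant, the group on the nitrogen on an aromatic ring now has a second readable step: an at least 8.3-fold higher number from compound 2 to compound 4 (0.92 log units; beyond the scatter). Most of the series still gives no number: the limit of > 100000 nM in this assay, at which 3 of the 4 values shown sit.

Going by these compounds, whether ring size matters where 3-chlorophenyl is present remains open. So does how morpholin-4-yl or an open-chain dimethylamino group would read on the same chain carbon.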